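Truncating the sulfonamide tail in the acylsulfonamide series

The source may report more compounds than this note shows. Statements on the series, on what has been measured and on what is new or still open speak of the compounds shown alone.

Measured so far in an ADME assay on microsomes from liver (Homo sapiens) for metabolic stability, with a stated time of 10 min; a lower number here means that less of the compound is left, a higher number that more of the compound is left:
compound 1 `CC(C)NCCS(=O)(=O)NC(=O)c1ccc(Nc2nc(NC3(c4ccc(Cl)cc4)CC3)nc(OCC(F)(F)F)n2)cc1`: 89%
compound 2 `CC(C)(C)OC(=O)NCCS(=O)(=O)NC(=O)c1ccc(Nc2nc(NC3(c4ccc(Cl)cc4)CC3)nc(OCC(F)(F)F)n2)cc1`: 92%
compound 3 `O=C(NS(=O)(=O)CCNCc1ccccc1)c1ccc(Nc2nc(NC3(c4ccc(Cl)cc4)CC3)nc(OCC(F)(F)F)n2)cc1`: 99%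

Compound 1 shows the lowest of the three numbers; the nearest is compound 2 (a number 3 percentage points higher from compound 1 to compound 2 (within the scatter)), the furthest compound 3 (a number 10 percentage points higher from compound 1 to compound 3 (within the scatter)), both within the scatter, as is a number 7 percentage points higher from compound 2 to compound 3 (within the scatter). All three differ only in the substituent on the amine nitrogen, and none shifts the read-out. Compound 4 `CS(=O)(=O)NC(=O)c1ccc(Nc2nc(NC3(c4ccc(Cl)cc4)CC3)nc(OCC(F)(F)F)n2)cc1` goes further: hydrogen in place of (isopropylamino)methyl on a saturated chain carbon bound to a sulfonyl sulfur. Within the data shown here, the chain itself is removed, which no measured step covers, so the three steps bear on it only indirectly; they show the tail tolerating changes without effect. Compound 4 is therefore expected to give 88% (range 74% to 99%). This estimate implies a number 1 percentage points lower from compound 1 to compound 4 (within the scatter), a step not expected to exceed the scatter.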

Compound 4, percent of the compound remaining: 100%
Compound 4: the middle estimate sits 12 percentage points below what was measured, and the stated range ends below it.
By their numbers in this assay, from the lowest: compounds 1, 2, 3 and 4 (each within the scatter of the next, the first and the last beyond it).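

In this assay, among these compounds, hydrogen in place of (isopropylamino)methyl gives the first step beyond the scatter, though a modest one (a number 11 percentage points higher from compound 1 to compound 4 (beyond the scatter)). The same truncation stays within the scatter against the other two tails (a number 1 percentage points higher from compound 3 to compound 4 (within the scatter); a number 8 percentage points higher from compound 2 to compound 4 (within the scatter)), so the 2-(isopropylamino)ethyl compound alone separates from the methylsulfonyl compound. Nothing at hand explains this difference.

Open, going by these compounds, is whether an ethyl group or a cyclopropyl group on the sulfonyl sulfur reads like the methyl of compound 4. Also open, on these data alone, is how a longer chain ending in a carboxylic acid would read.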